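The source may report more compounds than this note shows. Statements on the series, on what has been measured and on what is new or still open speak of the compounds shown alone.

Compound 2 `CC(=O)N[C@H](C(=O)N1C[C@H](O)C[C@H]1C(=O)N[C@@H](CCC(=O)O)c1ccc(-c2scnc2C)cc1)C(C)(C)C` gives -0.44 in a physicochemical assay for lipophilicity, measured as octanol-water partition, at pH 7.4 (a lower number here means a more polar compound, a higher number a more lipophilic compound), the lowest of the three numbers recorded; compound 3 `CCCC[C@H](NC(=O)[C@@H]1C[C@@H](O)CN1C(=O)[C@@H](NC(C)=O)C(C)(C)C)c1ccc(-c2scnc2C)cc1` gives 2.75 and compound 1 `CC(=O)N[C@H](C(=O)N1C[C@H](O)C[C@H]1C(=O)N[C@@H](CCC(C)(C)C)c1ccc(-c2scnc2C)cc1)C(C)(C)C` gives 3.21. The untested compound 4 `CC(=O)N[C@H](C(=O)N1C[C@H](O)C[C@H]1C(=O)N[C@@H](CCc1ccc(O)cc1)c1ccc(-c2scnc2C)cc1)C(C)(C)C` differs from compound 2 in one place: 4-hydroxyphenyl in place of carboxy on a saturated chain carbon, three bonds along the chain from an amide-type nitrogen and an aromatic carbon. Two measured steps at this position bear on the change. The move from carboxy to ethyl gave a number 3.19 log units higher from compound 2 to compound 3 (beyond the scatter), and the move from tert-butyl to carboxy gave a number 3.65 log units lower from compound 1 to compound 2 (beyond the scatter); both show that replacing the carboxy group at this carbon moves this assay by a large amount. A large rise is therefore expected for compound 4, about a number 3.44 log units higher from compound 2 to compound 4 (beyond the scatter). Compound 4 is thus estimated at 3, within a range of 2.4 to 3.6.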

Compound 4, distribution coefficient: 3.08
The estimate for compound 4 lay 0.08 log units below the measured number, within the range that was stated.
By their numbers in this assay, from the lowest: compound 2; then compound 3; then compounds 4 and 1 (each within the scatter of the next).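

The carboxy group is not alone in sitting far from the rest in this assay: a group that keeps a hydroxyl and brings in an aromatic ring also gives a large rise, a number 3.52 log units higher from compound 2 to compound 4 (beyond the scatter). The ring adds more than ethyl does, a number 0.33 log units higher from compound 3 to compound 4 (beyond the scatter), yet 4-hydroxyphenyl and tert-butyl cannot be told apart, a number 0.13 log units lower from compound 1 to compound 4 (within the scatter). Nothing shown here explains these steps. Going by these compounds, whether plain phenyl, without the hydroxyl, would stand with compound 4 remains open, and so does the effect of an amine at this carbon.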